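The source may hold more compounds than are shown below. What is called first, only, known or untested is meant among the compounds shown, and "the series" means these compounds.

Of the compounds shown here, three on the shared core have been measured in an assay on isolated protein for inhibition of endoplasmic reticulum aminopeptidase 1 (Homo sapiens), with stated times of 15 min and 20 min; a higher number here means a weaker inhibitor, a lower number a stronger inhibitor. Compound 1 `O=C(NC1(C(=O)O)CCCCC1)c1cccc2c(Br)c(-c3ccc(Cl)cc3)oc12` gives 151 nM in this assay. Compound 3 `CC(C)(NC(=O)c1cccc2cc(-c3ccc(Cl)cc3)oc12)C(=O)O` gives 1030 nM in this assay, and compound 2 `CN(C(=O)c1cc(F)cc2cc(-c3ccc(Cl)cc3)oc12)C(C)(C)C(=O)O` gives 1970 nM in this assay, the highest number of the three, within the scatter of compound 3 but well beyond it against compound 1. Compound 4 `O=C(NC1(C(=O)O)CCCC1)c1cc(F)cc2cc(-c3ccc(Cl)cc3)oc12` has not yet been measured; it differs from compound 2 in one place: (1-carboxycyclopentyl)amino in place of (1-carboxy-1-methylethyl)(methyl)amino on a carbonyl carbon. Among the compounds with values here, no measured pair shows this exact change. Compound 3 keeps the amide hydrogen, and its 1030 nM sits within the scatter of compound 2. Compound 1 carries a ring-closed acid and shows the lowest number, and a ring-closed acid enters in compound 4. The step from compound 2 to compound 4 is expected to be a moderate fall, a 4.4-fold lower number from compound 2 to compound 4 (0.64 log units; beyond the scatter). Compound 4 is estimated at 450 nM, within 150 nM to 1300 nM.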

Compound 4, half-maximal inhibitory concentration: 99 nM
The estimate for compound 4 lay 4.5-fold (0.66 log units) above the measured number, and the stated range ends above it.
By their numbers in this assay, from the lowest: compounds 4 and 1 (each within the scatter of the next); then compounds 3 and 2 (each within the scatter of the next).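

The change on a carbonyl carbon, (1-carboxycyclopentyl)amino in place of (1-carboxy-1-methylethyl)(methyl)amino, gives in this assay a large step, a 20-fold lower number from compound 2 to compound 4 (1.30 log units; beyond the scatter), the first single-place step measured at this position. It brings in a five-membered ring of carbon only and restores the amide hydrogen at once, so this one pair cannot separate the two. Nothing measured here explains the fall.

The compounds shown leave open which of the two parts carries the step. They also leave open how a (1-carboxycyclopropyl)amino group would read at this position on the core of compound 4.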